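The source may report more compounds than this note shows. Statements on the series, on what has been measured and on what is new or still open speak of the compounds shown alone.

Three members of the series have numbers in a functional assay on the whole organism for inhibition, with Brassica napus as the target, with a stated time of 72 h, tested at 10 mg/L; on this read-out lower numbers stand for less inhibition of growth and higher numbers for more inhibition of growth at the one concentration tested. Compound 1 `Cc1cc(O)nc(NC(=S)NC(=O)c2c(-c3ccc(Cl)cc3Cl)noc2C)n1` gives 6.7%. Compound 2 `CSc1cc(C)nc(NC(=S)NC(=O)c2c(-c3ccc(Cl)cc3Cl)noc2C)n1` gives 42.4%. Compound 3 `Cc1cc(Cl)nc(NC(=S)NC(=O)c2c(-c3ccc(Cl)cc3Cl)noc2C)n1` gives 8.36%, the second highest of the three; its gap to compound 1 is within the scatter, a number 1.7 percentage points higher from compound 1 to compound 3 (within the scatter), whereas the gap to compound 2 is large, a number 34 percentage points lower from compound 2 to compound 3 (beyond the scatter). The next member, compound 4 `COc1cc(OC)nc(NC(=S)NC(=O)c2c(-c3ccc(Cl)cc3Cl)noc2C)n1`, differs from compound 3 by 4,6-dimethoxypyrimidin-2-yl in place of 4-chloro-6-methylpyrimidin-2-yl on an amide-type nitrogen. Among the measured compounds shown here, no measured step exchanges a methoxy group, so the bearing on this change is indirect. On the aromatic carbon in question a hydroxy and a chloro give numbers within the scatter of each other, and only the methylsulfanyl moved the read-out far, a number 35.7 percentage points higher from compound 1 to compound 2 (beyond the scatter). For the measured compounds named here, the entering group carries oxygen, as does the hydroxy of compound 1, not sulfur; the methyl that leaves has no step of its own. The expected step in this assay is therefore small, upward if at all, a number 9.6 percentage points higher from compound 3 to compound 4 (within the scatter). Compound 4 is estimated at 18%, within 2% to 45%.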

Compound 4, percent growth inhibition at one concentration: 35.2%
Estimate against measurement, compound 4: 17.2 percentage points below; the measured number falls inside the stated range.
By their numbers in this assay, from the lowest: compounds 1 and 3 (each within the scatter of the next); then compounds 4 and 2 (each within the scatter of the next).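

In this assay, a high number in this series does not depend on sulfur: 4,6-dimethoxypyrimidin-2-yl on the amide-type nitrogen raises the read-out over the chloro compound (a number 26.8 percentage points higher from compound 3 to compound 4 (beyond the scatter)) and the hydroxy compound (a number 28.5 percentage points higher from compound 1 to compound 4 (beyond the scatter)), and stays within the scatter of the methylsulfanyl compound (a number 7.2 percentage points lower from compound 2 to compound 4 (within the scatter)). Oxygen in the entering group therefore does not by itself keep the number low, since the hydroxy and dimethoxy compounds fall well apart. No measurement at hand accounts for this separation.

From the compounds shown here alone, the step replaces the chloro and the methyl together, so it remains open which of the two methoxy groups carries it, or whether both are needed. Also open, going by these compounds, is how an amine or an ethoxy chain would read in the same setting.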